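The source may report more compounds than this note shows. Statements on the series, on what has been measured and on what is new or still open speak of the compounds shown alone.

Series notes. The series is assessed in an assay on isolated protein for activation of Nicotinamide phosphoribosyltransferase (Homo sapiens); a lower number here means that less compound is needed, a higher number that more compound is needed for the effect. Compound 1 `O=C(NCc1ccncc1)Nc1ccc(S(=O)(=O)Nc2ccccc2)cc1` gives 410 nM in this assay, and compound 2 `CCOC(=O)c1ccc(NC(=O)NCc2cocn2)cc1` gives 27600 nM. Among the measured compounds shown here, of the two numbers so far, compound 2 stands at the highest; the nearest measured neighbour is compound 1, whose number is far lower, and the gap between the two lies beyond the scatter of repeated measurements. For the measured compounds named here, the two compounds share the urea link but differ in more than one place, so no single step between them can be read.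

Compound 3 `CCOC(=O)c1ccc(NC(=O)NCc2cn[nH]c2)cc1` keeps the core of compound 2 and changes only the five-membered ring: 1H-pyrazol-4-yl in place of 1,3-oxazol-4-yl on a saturated chain carbon bound to an amide-type nitrogen. The ring size and the count of heavy atoms stay the same; what changes is the pattern of donor and acceptor in the ring. Going by the values given here, no measured pair shows this change, so its size is unknown here. A small step in this assay is expected, of the order of the scatter or little beyond it, without a firm direction, as a 1.4-fold lower number from compound 2 to compound 3 (0.14 log units; within the scatter). For compound 3 the estimate in this assay is 20000 nM, within a range from 7000 nM to 60000 nM.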

Compound 3, half-maximal effective concentration: 1850 nM
The estimate for compound 3 lay 11-fold (1.03 log units) above the measured number, outside the stated range (below it).
By their numbers in this assay, from the lowest: compound 1; then compound 3; then compound 2.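

In this assay, the five-membered ring on a saturated chain carbon bound to an amide-type nitrogen proves to be a sensitive point in the series: 1H-pyrazol-4-yl in place of 1,3-oxazol-4-yl gives a 15-fold lower number from compound 2 to compound 3 (1.17 log units; beyond the scatter) and the rest of the structure stays the same. Ring size and heavy-atom count are unchanged, so the step goes with a change in ring atoms and in the counted pattern, from 0 hydrogen-bond donors and 2 hydrogen-bond acceptors to 1 hydrogen-bond donor and 1 hydrogen-bond acceptor. No available data bear on the reason for this step, so the counts remain a description of the change and not an explanation.
From the compounds shown here alone, whether the ring's donor hydrogen matters remains open, and a 1-methyl-1H-pyrazol-4-yl group at the same place would separate that hydrogen from the ring's other features. Among the compounds shown here, no step to compound 1 can be read, as it differs from the other two compounds in more than one place, and the effect of replacing the ethyl ester with a carboxylic acid or an amide also remains open.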